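Removing the Ring Amide Methyl from a Macrocyclic Scaffold

The source may hold more compounds than are shown below. What is called first, only, known or untested is meant among the compounds shown, and "the series" means these compounds.

Measured in a functional assay on L1210 cells (Mus musculus) for cytotoxicity; a higher number here means a weaker inhibitor, a lower number a stronger inhibitor:
compound 1 `COC(=O)[C@@H]1Cc2ccc(OC)c(c2)Oc2ccc(cc2)C[C@H](N(C)C(=O)OC(C)(C)C)C(=O)N1C` gives 0.03 ug/mL.
compound 2 `COc1ccc2cc1Oc1ccc(cc1)CCC(=O)N(C)CC2` gives > 100 ug/mL, which is a limit of the assay and not a number.
compound 3 `COC(=O)[C@@H]1Cc2ccc(OC)c(c2)Oc2ccc(cc2)C[C@H](N(C)C(=O)OC(C)(C)C)C(=O)N1` gives 0.06 ug/mL.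

Compound 3 arises from compound 1 by hydrogen in place of methyl on an amide-type nitrogen in a ring, and the step is a 2.0-fold higher number from compound 1 to compound 3 (0.30 log units; within the scatter). Compound 4 `COc1ccc2cc1Oc1ccc(cc1)CCC(=O)NCC2` arises from compound 2 by hydrogen in place of methyl on an amide-type nitrogen in a ring. How the cores of compound 1 and compound 2 differ is not broken down here. The surroundings of the change are not identical: in compound 1 the nitrogen is next to the ring atom that bears a methoxycarbonyl group and two ring bonds from the ring atom that bears a methyl(tert-butoxycarbonyl)amino group, while in compound 2 it is only six ring bonds from the ring oxygen, so this is the same kind of change rather than the same change. Compound 2 sits at the limit of > 100 ug/mL in this assay, at which 1 of the 3 values shown sits. Because a 2.0-fold higher number from compound 1 to compound 3 (0.30 log units; within the scatter) is within the scatter, compound 4 is expected to remain at the limit, with an expected step that the limit leaves unreadable from compound 2 to compound 4. Compound 4 is therefore estimated at 150 ug/mL.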

Compound 4, half-maximal inhibitory concentration: > 100 ug/mL
Compound 4: a limit, no number; the forecaster's own chance of this, stated with the estimate: 90%; the middle value lies beyond the limit too.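

The step between compound 2 and compound 4 cannot be read: both results are limits of the assay, not numbers. The compounds shown leave open whether hydrogen in place of methyl changes the read-out at all on the core of compound 2.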